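Exchanging the aryl group on the ring nitrogen: compound 3 to compound 4

The source may hold more compounds than are shown below. What is called first, only, known or untested is meant among the compounds shown, and "the series" means these compounds.

Of the compounds shown here, three sharing one core have been tested in a functional assay on PC-3 cells (Homo sapiens) for inhibition, read by MTT assay, with a stated time of 72 h; on this read-out lower numbers stand for stronger inhibition and higher numbers for weaker inhibition. Compound 1 `C=CC(=O)Nc1cccc(NC(=O)CSc2nc(Nc3ccccc3F)c3ccccc3n2)c1` gives 9340 nM. Compound 2 `C=CC(=O)Nc1cccc(NC(=O)CSc2nc(Nc3cccc([N+](=O)[O-])c3)c3ccccc3n2)c1` gives 46300 nM. For compound 3 `C=CC(=O)Nc1cccc(NC(=O)CSc2nc(Nc3cc(OC)c(OC)c(OC)c3)c3ccccc3n2)c1` this assay reports only a limit, > 50000 nM. Compound 3 thus sits at the limit of > 50000 nM in this assay, at which 1 of the 3 values shown sits, and its place relative to the other two is known only from one side: an at least 5.3-fold higher number from compound 1 to compound 3 (0.72 log units; beyond the scatter), and an at least 1.0-fold higher number from compound 2 to compound 3 (0.03 log units; that floor lies within the scatter).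

Compound 4 `C=CC(=O)Nc1cccc(NC(=O)CSc2nc(Nc3ccc(Cl)c(Cl)c3)c3ccccc3n2)c1` differs from compound 3 in a single place: 3,4-dichlorophenyl in place of 3,4,5-trimethoxyphenyl on a nitrogen on an aromatic ring. Within the data shown here, no measured step makes this exact exchange. The steps that involve the group on that nitrogen all point the same way: a 5.0-fold higher number from compound 1 to compound 2 (0.70 log units; beyond the scatter) connects the two fully measured compounds, and an at least 5.3-fold higher number from compound 1 to compound 3 (0.72 log units; beyond the scatter) ends at the limit. Every exchange of that group seen so far has moved the number upward or left it at the limit, and none shows what a 3,4-dichlorophenyl does in that position.

Compound 4 is expected to land toward the weak end, around 20000 nM, estimated between 5000 nM and 50000 nM. That estimate means that the step of an at least 2.5-fold lower number from compound 3 to compound 4 (0.39 log units; beyond the scatter) is expected, with a fair chance that this assay again reports only a limit.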

Compound 4, half-maximal inhibitory concentration: 27600 nM
For compound 4 the middle estimate is 1.4-fold (0.14 log units) below the measured one; low and high end bracket the measured number.
By their numbers in this assay, from the lowest: compound 1; then compounds 4 and 2 (each within the scatter of the next). At a limit, above all of these: compound 3.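

In this assay, a 3.0-fold higher number from compound 1 to compound 4 (0.47 log units; beyond the scatter), so the 3,4-dichlorophenyl group joins the 3-nitrophenyl and 3,4,5-trimethoxyphenyl groups in giving a higher number than the 2-fluorophenyl group of compound 1 at this position. Among the groups with a measured value, the new one does not separate from the nitro-bearing one: a 1.7-fold lower number from compound 2 to compound 4 (0.22 log units; within the scatter), so these two exchanges cannot be put in order in this assay. The exchange of 3,4,5-trimethoxyphenyl for 3,4-dichlorophenyl gives an at least 1.8-fold lower number from compound 3 to compound 4 (0.25 log units; that floor lies within the scatter), which cannot be read as a real gain, and its starting point remains a limit of the assay rather than a number: the limit of > 50000 nM in this assay, at which 1 of the 4 values shown sits.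

As far as these compounds go, what an unsubstituted phenyl or a 2-chlorophenyl would give on that nitrogen stays open, and with it whether the lower number of compound 1 goes with the fluorine itself or with any small group in that place. Also open, from the compounds shown here alone, is whether an amine or a methoxy group on the phenyl ring could bring the number below that of compound 1, at 9340 nM.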